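The source may hold more compounds than are shown below. What is called first, only, known or untested is meant among the compounds shown, and "the series" means these compounds.

Compound 1 `O=C(O)/C=C/c1ccc(Cn2cccn2)cc1OCCc1ccc2ccccc2c1` gives 2900 nM in an assay on CHO cells for displacement of a labelled ligand from prostaglandin E2 receptor EP1 subtype (Mus musculus), read by scintillation counting; a higher number here means a weaker inhibitor, a lower number a stronger inhibitor. Compound 2 `O=C(O)/C=C/c1ccc(COc2ccccc2)cc1OCCc1ccc2ccccc2c1` reaches only the assay limit there, > 10000 nM. Compound 3 `O=C(O)C#Cc1ccc(Cn2cccn2)cc1OCCc1ccc2ccccc2c1` likewise reaches only the assay limit, > 10000 nM. Because of the limit of > 10000 nM in this assay, at which 2 of the 3 values shown sit, compound 3 stands at the weak end of what is shown, without a number of its own. The step of an at least 3.4-fold higher number from compound 1 to compound 3 (0.53 log units; beyond the scatter) shows how much the change of the acid arm cost; the step of an at least 3.4-fold higher number from compound 1 to compound 2 (0.53 log units; beyond the scatter) concerns a different part of the molecule. Compound 4 `O=C(O)CCCc1ccc(Cn2cccn2)cc1OCCc1ccc2ccccc2c1` carries yet another acid arm: 3-carboxypropyl in place of 2-carboxyethynyl on an aromatic carbon. Going by the values given here, no measured step covers this chain, so the direction from compound 3 is open; only the step of an at least 3.4-fold higher number from compound 1 to compound 3 (0.53 log units; beyond the scatter) shows that the acid arm matters. Compound 4 is therefore expected at 6000 nM, with a range from 2000 nM to 20000 nM, the expected step being an at least 1.6-fold lower number from compound 3 to compound 4 (0.22 log units; that floor lies within the scatter).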

Compound 4, inhibition constant: 4000 nM
For compound 4 the middle estimate is 1.5-fold (0.18 log units) above the measured one; measured number inside the range.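

Swapping the rigid-looking name aside, 3-carboxypropyl in place of 2-carboxyethynyl gives an at least 2.5-fold lower number from compound 3 to compound 4 (0.39 log units; beyond the scatter), so a stronger inhibitor returns once the triple bond is gone from this arm. Against the 2-carboxyethenyl arm the change gives a 1.4-fold higher number from compound 1 to compound 4 (0.14 log units; within the scatter), so these two arms cannot be told apart, and among compounds 1, 3 and 4 only the 2-carboxyethynyl arm stands out. The first step is only a floor, because compound 3 has no number of its own: the limit of > 10000 nM in this assay, at which 2 of the 4 values shown sit.

Open, on these data alone, is whether a shorter 2-carboxyethyl chain or a longer 4-carboxybutyl chain would serve equally well. Also open, as far as these compounds go, is whether an amide could stand in for the carboxylic acid.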